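The compounds below may be only part of what the source reports. "The series", "measured", "known", "first", "only" and "open" are said of these compounds alone.

Measured compounds in a functional assay on SK-MEL-28 cells (Homo sapiens) for cytotoxicity, read by MTT assay; a higher number here means a weaker inhibitor, a lower number a stronger inhibitor:
Compound 1 `Cc1ccc(S(=O)(=O)NCCCNc2nccc(-c3c(-c4cccc(F)c4)nc4sccn34)n2)cc1` gives 9500 nM.
Compound 2 `O=S(=O)(NCCNc1nccc(-c2c(-c3cccc(F)c3)nc3sccn23)n1)c1cccc(F)c1` gives 18300 nM.
Compound 3 `Cc1ccc(C(=O)NCCNc2nccc(-c3c(-c4cccc(F)c4)nc4sccn34)n2)cc1` gives 18800 nM.

Compound 1 holds the lowest number of the three, but its steps to the others, a 1.9-fold higher number from compound 1 to compound 2 (0.28 log units; within the scatter) and a 2.0-fold higher number from compound 1 to compound 3 (0.30 log units; within the scatter), are both within the scatter, so no order among the three can be read from these numbers. The step between the other two, a 1.0-fold higher number from compound 2 to compound 3 (0.01 log units; within the scatter), is likewise within the scatter.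

Compound 4 `COc1ccc(S(=O)(=O)NCCCNc2nccc(-c3c(-c4cccc(F)c4)nc4sccn34)n2)cc1` differs from compound 1 in one place: methoxy in place of methyl on an aromatic carbon. For the measured compounds named here, none of the measured steps exchanges methyl for methoxy, so no step bears directly on this change; the three measured changes concern other groups, and none of them moved the number beyond the scatter. With nothing pointing in either direction, the working assumption is that the number stays close to that of compound 1. The expected step from compound 1 to compound 4 is no change at the digits printed from compound 1 to compound 4 (within the scatter), meaning none beyond the scatter. Compound 4 is therefore estimated at 9500 nM, with a range from 4000 nM to 22000 nM.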

Compound 4, half-maximal inhibitory concentration: 8980 nM
Compound 4: the middle estimate sits 1.1-fold (0.02 log units) above what was measured, within the range that was stated.
By their numbers in this assay, from the lowest: compounds 4, 1, 2 and 3 (each within the scatter of the next, the first and the last beyond it).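

In this assay, methoxy in place of methyl on the aromatic carbon para to a large group gives a 1.1-fold lower number from compound 1 to compound 4 (0.02 log units; within the scatter), so within the scatter this position accepts the extra oxygen and hydrogen-bond acceptor without a readable shift. The earlier steps shown here exchanged the whole sulfonyl or carbonyl unit, some with the chain as well, whereas this step changes only the group on the ring of the 4-methylphenyl unit, keeping the sulfonyl and the chain of compound 1. No measurement here offers an explanation for this outcome.

As far as these compounds go, whether a carboxylic acid or a dimethylamino group at the same position would move the number beyond the scatter remains open. So does the effect of a longer chain on the 4-methoxyphenyl series.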